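A few compounds are considered here, and "the series" means these few. Any claim that something is new, unique, unknown or untested is made for them only; others in the source may bear on it.

Measured compounds:
compound 1, `O=C(O)[C@H]1NC[C@H](O)[C@H](O)[C@H]1O`, gives 7.6% in an assay on isolated protein for inhibition of cytosolic endo-beta-N-acetylglucosaminidase (Homo sapiens), tested at 1000 uM; on this read-out lower numbers stand for less inhibition and higher numbers for more inhibition at the one concentration tested (going by the name of the read-out)
compound 2, `O=C(O)[C@@H]1NC[C@H](O)[C@@H](O)[C@@H]1O`, gives 5.4%
compound 3, `O=C(O)[C@H]1NC[C@@H](O)[C@@H](O)[C@@H]1O`, gives 28%

Compound 1 stands second highest of the three numbers. The step of a number 2.2 percentage points lower from compound 1 to compound 2 (within the scatter) stays inside the scatter, whereas a number 20.4 percentage points higher from compound 1 to compound 3 (beyond the scatter) goes beyond it, as does a number 22.6 percentage points higher from compound 2 to compound 3 (beyond the scatter). All three steps are changes of configuration alone the fact that compounds 1 and 2 differ only in the configuration as drawn the fact that compounds 1 and 3 differ only in the configuration as drawn (the fact that compounds 2 and 3 differ only in the configuration as drawn), each involving two or three stereocentres.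

Compound 4, `O=C(O)[C@H]1NC[C@H](O)[C@H](O)[C@@H]1O`, differs from compound 1 by a smaller change: the two compounds have the same atoms and bonds and differ only in configuration as drawn: 1 of 4 stereo elements differ; a stereocentre at a saturated ring carbon is drawn S in compound 1 and R in compound 4. Since inverting three stereocentres gave either no shift beyond the scatter or a modest rise, a move within the scatter or a slight rise is expected in this assay, namely a number 4.4 percentage points higher from compound 1 to compound 4 (within the scatter). Compound 4 is therefore estimated at 12%, with a range from 3% to 30%.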

Compound 4, a percentage reported as inhibition, at one concentration (the size of the read-out at that concentration, not a potency): 26%
The estimate for compound 4 lay 14 percentage points below the measured number, and the stated range covers the measured number.
By their numbers in this assay, from the lowest: compounds 2 and 1 (each within the scatter of the next); then compounds 4 and 3 (each within the scatter of the next).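

In this assay, among these compounds, inverting a single stereocentre at a saturated ring carbon gives a number 18.4 percentage points higher from compound 1 to compound 4 (beyond the scatter), so one centre alone can produce a shift that the earlier compounds showed only with two or three centres changed: the fact that compounds 1 and 4 differ only in the configuration as drawn. The change also brings compound 4 level with compound 3, with a number 2 percentage points lower from compound 3 to compound 4 (within the scatter), although the two differ at two stereocentres, while a number 20.6 percentage points higher from compound 2 to compound 4 (beyond the scatter) sets it clear of the low end.

As far as these compounds go, whether each remaining stereocentre can move the number on its own stays open. So does the effect of replacing the carboxylic acid with a primary amide or a hydroxymethyl group.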